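Removing an Ethyl Group from an Ester Side Chain

This account rests on a few compounds, and the source may have more. Where it says the series, first, only, none or still open, it means among the compounds named here.

Measured compounds:
compound 1, `CC(C)(O)c1cn(-c2ccnc3cc(Cl)ccc23)nn1`: 442000 nM
compound 2, `CCc1ccc(C(=O)OCc2cn(-c3ccnc4cc(Cl)ccc34)nn2)cc1`: > 2550000 nM

Both compounds share a core carrying a triazole; they differ in what hangs from that triazole. In an ADME assay on HepG2 cells (Homo sapiens) for cytotoxicity, read by MTT assay, with a stated time of 24 h (a lower number here means that less compound is tolerated, a higher number that more compound is tolerated), compound 1 gives 442000 nM, a measured number. For compound 2 the value > 2550000 nM is not a number but a limit of the assay. In other words, compound 2 stands at the limit of > 2550000 nM in this assay, at which 1 of the 2 values shown sits.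

Compound 3, `O=C(OCc1cn(-c2ccnc3cc(Cl)ccc23)nn1)c1ccccc1`, differs from compound 2 by hydrogen in place of ethyl on an aromatic carbon, para to a large group, so that the 4-ethylphenyl of compound 2 becomes a plain phenyl. For the measured compounds named here, no measured pair shows this change, so the expectation rests on compound 2 alone. The step from compound 2 to compound 3 is expected to be an at least 1.2-fold lower number from compound 2 to compound 3 (0.10 log units; that floor lies within the scatter), with no direction beyond the usual scatter.

Compound 3 is therefore expected near 2000000 nM, in the range 700000 nM to 3500000 nM, and it may again be reported only as a limit.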

Compound 3, half-maximal cytotoxic concentration: > 2740000 nM
Compound 3: a limit, no number; the forecaster's own chance of this, stated with the estimate: 55%; middle value at least 1.3-fold (0.13 log units) from the limit.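

Compound 2 and compound 3 are each reported only as a limit, not as a number, so the step between them cannot be read. The compounds shown leave open whether replacing the 4-ethylphenyl with a plain phenyl changes how much compound the cells tolerate, and if it does, in which direction and by how much.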